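From methoxy to chloro on an aromatic carbon

The source may report more compounds than this note shows. Statements on the series, on what has been measured and on what is new or still open speak of the compounds shown alone.

Measured so far in a physicochemical assay for solubility, in phosphate buffer, at pH 7.4; a higher number here means a more soluble compound, a lower number a less soluble compound
Compound 1 `COc1ccc(CNC(=O)c2c(C)nc3cc(C)ccn23)cc1` gives 148000 nM
Compound 2 `COc1cccc(CNC(=O)c2c(C)nc3cc(C)ccn23)c1` gives 149000 nM

Among the compounds with values here, compound 1 stands level with compound 2, the only other compound measured, as their two values lie within the scatter of each other. Compound 3 `Cc1ccn2c(C(=O)NCc3ccc(Cl)cc3)c(C)nc2c1` has chloro in place of methoxy on an aromatic carbon, para to a large group (chloro in place of methoxy on an aromatic carbon). Within the data shown here, no measured pair yet tests this kind of change, so any expectation is loose. In this assay a moderate fall beyond the scatter is expected, with the estimated step being a 2.5-fold lower number from compound 1 to compound 3 (0.39 log units; beyond the scatter) in size. Compound 3 is expected at 60000 nM (range 20000 nM to 140000 nM).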

Compound 3, solubility: 25000 nM
The estimate for compound 3 lay 2.4-fold (0.38 log units) above the measured number; measured number inside the range.
By their numbers in this assay, from the lowest: compound 3; then compounds 1 and 2 (each within the scatter of the next).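

In this assay, chloro in place of methoxy on this aromatic carbon, para to a large group, gives a 5.9-fold lower number from compound 1 to compound 3 (0.77 log units; beyond the scatter), so the group here can move the number beyond the scatter, at least in this one pair. Compound 1 and compound 2 had shown no such separation. Nothing measured here bears on why the number falls.

Going by these compounds, whether an amine or a carboxylic acid on this carbon would give a higher number than compound 1 remains open. On these data alone, it is also open whether chloro in place of the methoxy of compound 2 would give a similar step.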